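This account rests on a few compounds, and the source may have more. Where it says the series, first, only, none or still open, it means among the compounds named here.

Of the compounds shown here, two have been measured in an assay on isolated protein for inhibition of Rho-associated protein kinase 2 (Homo sapiens) (a higher number here means a weaker inhibitor, a lower number a stronger inhibitor), so far. Compound 1, with the structure `COc1cccc(CN(CCCN(C)C)C(=O)c2cn(C)c3cc(-c4cn[nH]c4)ccc23)c1`, gives 1 nM. Compound 2, with the structure `COc1cccc(CNC(=O)c2cn(-c3ccccc3)c3cc(-c4cn[nH]c4)ccc23)c1`, gives 5 nM in this assay. That leaves compound 2 with the higher of the two numbers, and the gap to compound 1 lies beyond the usual scatter of repeated measurements; compound 1 and compound 2 differ from each other in more than one place, so the gap cannot be tied to a single change.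

The next compound, compound 3, has the structure `COc1cccc(CNC(=O)c2cn(C)c3cc(-c4cn[nH]c4)ccc23)c1`. It differs from compound 2 in one place only: methyl in place of phenyl on an aromatic nitrogen. Compound 3 also shares its methyl-bearing core with compound 1, while carrying the simpler amide of compound 2.

Since both measured compounds are strong inhibitors, compound 3 is expected to stay in the same region, with a step from compound 2 of a 1.7-fold lower number from compound 2 to compound 3 (0.22 log units; within the scatter) that may or may not clear the scatter. The estimate for compound 3 in this assay is 3 nM, with a plausible range from 1 nM to 10 nM.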

Compound 3, half-maximal inhibitory concentration: < 1 nM
Compound 3 ended at the assay's limit; the forecaster's own chance of this, stated with the estimate: 2%; middle value at least 3.0-fold (0.47 log units) away from the limit.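

In this assay compound 3 gives < 1 nM, which is a limit of the assay and not a number. Even so, putting methyl in place of phenyl on the aromatic nitrogen gives an at least 5.0-fold lower number from compound 2 to compound 3 (0.69 log units; beyond the scatter), so for the first time a gap beyond the scatter can be tied to a single change, and at this position the smaller of the two groups gives the stronger inhibitor. The full size of that step stays unknown, and putting hydrogen in place of the 3-(dimethylamino)propyl chain on the amide-type nitrogen gives a number no higher from compound 1 to compound 3 (the limit leaves the size open), a step whose size cannot be read, because the values concerned reach the limit: the limit of < 1 nM in this assay, at which 1 of the 3 values shown sits.

The compounds shown carry only phenyl and methyl on the aromatic nitrogen, which leaves open where a hydrogen, an ethyl group or a benzyl group would fall. As far as these compounds go, it also stays open whether the 3-(dimethylamino)propyl chain on the amide-type nitrogen changes inhibition at all, and whether a shorter chain or one ending in a morpholine would do so on the same core.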